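The source may hold more compounds than are shown below. What is called first, only, known or untested is meant among the compounds shown, and "the series" means these compounds.

Of the compounds shown here, three built on one shared core have been measured in a functional assay; a higher number here means that more compound is needed for the effect, a lower number that less compound is needed. Compound 1 `Cc1sc2c(Nc3ccc(C#N)cc3)cccc2c1C` reaches only a limit of the assay, giving > 250 ug/mL. Compound 2 `Cc1sc2c(Nc3cccnc3)cccc2c1C` likewise gives only a limit, > 250 ug/mL. For the measured compounds named here, compound 3 `COc1ccc(Nc2cccc3c(C)c(C)sc23)cc1OC` is the single compound with a number in this assay, where it gives 22.7 ug/mL. Compounds 1 and 2 together account for (the limit of > 250 ug/mL in this assay, at which 2 of the 3 values shown sit). Going by the values given here, compound 3 thus stands alone as the one measurable value among the three, and no step between measured compounds can be drawn from it.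

Compound 4 `COc1ccc(Nc2cccc3c(C)c(C)sc23)cc1` has not yet been measured. It differs from compound 3 by hydrogen in place of methoxy on an aromatic carbon. With no measured step of this kind shown, the direction is open; the two compounds that reach only the limit, compound 1 and compound 2, both lack any methoxy group, while compound 3, the one with a number, carries two, so a loss on removing one methoxy is the more likely expectation, of modest size but possibly beyond the scatter. On that basis compound 4 is expected to give about 50 ug/mL in this assay, within a range from 15 ug/mL to 250 ug/mL. The expected step of a 2.2-fold higher number from compound 3 to compound 4 (0.34 log units; beyond the scatter) would thus be a small loss.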

Compound 4, half-maximal effective concentration: 21.6 ug/mL
Compound 4: middle estimate off by 2.3-fold (0.36 log units), on the high side; measured number inside the range.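

In this assay, hydrogen in place of methoxy on this aromatic carbon, ortho to a methoxy group, gives a 1.1-fold lower number from compound 3 to compound 4 (0.02 log units; within the scatter), so the methoxy group at this position makes no difference that can be read beyond the scatter. For the compounds shown here, the one methoxy group that compound 4 retains is enough to give a measurable value, and methoxy in place of cyano gives an at least 11-fold lower number from compound 1 to compound 4 (1.06 log units; beyond the scatter), a large step that the earlier compounds could not show. The true size of that step remains unknown, as compound 1 gives only a limit of the assay, and the step is therefore a minimum: the limit of > 250 ug/mL in this assay, at which 2 of the 4 values shown sit.

The compounds shown leave open whether the remaining methoxy group can itself be replaced by hydrogen, and how a hydroxyl group, an amine or a longer alkoxy chain such as ethoxy would read in its place. They also leave open whether any group other than methoxy on the carbon ortho to it, such as fluorine or a carboxylic acid, would move the value beyond the scatter in this assay.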